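A few compounds are considered here, and "the series" means these few. Any claim that something is new, unique, unknown or untested is made for them only; others in the source may bear on it.

Measured so far:
compound 1, `O=S(=O)(CC1=NCCS1)c1c(-c2ccccc2)noc1-c1ccccc1`: "not active" (no number reported)
compound 2, `COc1ccc(C2=NOC(c3ccc(C)cc3)C2S(=O)(=O)CC2=NCCS2)cc1`: 49.7%

In a functional assay, tested at 75 ug/mL (on this read-out lower numbers stand for a weaker effect and higher numbers for a stronger effect at the one concentration tested), compound 1 is reported as "not active" (no number reported), so no single number places it on the scale. Compound 2 differs from compound 1 in several places; in this assay compound 2 gives 49.7%. Among the measured compounds shown here, no single step links compound 1 and compound 2. Compound 3, `O=S(=O)(CC1=NCCO1)c1c(-c2ccccc2)noc1-c1ccccc1`, differs from compound 1 in one place: a group of 5 heavy atoms (3 carbon, 1 nitrogen, 1 oxygen; one five-membered non-aromatic ring with 2 hetero atoms) in place of a group of 5 heavy atoms (3 carbon, 1 nitrogen, 1 sulfur; one five-membered non-aromatic ring with 2 hetero atoms), on a saturated chain carbon bound to a sulfonyl sulfur. For the measured compounds named here, no measured step of this kind is available, so only a small shift is expected, if any beyond the scatter, and compound 3 is expected to remain weak. For compound 3 the estimate in this assay is 10%, within 0% to 30%.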

Compound 3, a percentage reported as activity, at one concentration (the size of the read-out at that concentration, not a potency): 58.1%
Compound 3: middle estimate off by 48.1 percentage points, on the low side; measured number outside the range, above it.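

No step can be read from compound 1 to compound 3, as compound 1 has no number on the scale. The compounds shown leave open how large the effect of this ring change is. No supporting evidence bears on this result.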